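Chloro to trifluoromethyl on the core of compound 1

The source may hold more compounds than are shown below. What is called first, only, known or untested is meant among the compounds shown, and "the series" means these compounds.

- compound 1 `O=C1C(=O)C2C(N=C3N=NNN3C23C(=O)Nc2c(Cl)cccc23)c2ccccc21` gives 49500 nM as its value
- compound 2 `O=C1C(=O)C2C(N=C3N=NNN3C23C(=O)Nc2ccc(F)cc23)c2ccccc21` gives 58900 nM as its value

Both numbers come from a functional assay on L02 cells (Homo sapiens) for antiproliferative activity, read by MTT assay (on this read-out higher numbers stand for weaker inhibition and lower numbers for stronger inhibition), and they lie within the scatter of each other, so compound 1 stands level with compound 2 and neither can be ranked on these data. Compound 3 `O=C1C(=O)C2C(N=C3N=NNN3C23C(=O)Nc2c(C(F)(F)F)cccc23)c2ccccc21` keeps the core of compound 1 and carries trifluoromethyl in place of chloro on an aromatic carbon, ortho to a fused ring (trifluoromethyl in place of chloro on an aromatic carbon). Going by the values given here, no measured pair here differs in one place, so this assay offers no direct step to lean on for this exchange. Among the compounds with values here, the only guide is the narrow spread of the two values, with compound 1 at 49500 nM and compound 2 at 58900 nM on the same scale. The estimated outcome is a 1.0-fold higher number from compound 1 to compound 3 (0.00 log units; within the scatter) and so no shift beyond the scatter is expected in either direction. Compound 3 is expected at 50000 nM with an estimated range from 22000 nM to 110000 nM in this read-out.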

Compound 3, half-maximal inhibitory concentration: 49900 nM
Compound 3: middle estimate off by 1.0-fold (0.00 log units), on the high side; measured number inside the range.
By their numbers in this assay, from the lowest: compounds 1, 3 and 2 (each within the scatter of the next).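

In this assay, going by these compounds alone, trifluoromethyl in place of chloro on an aromatic carbon, ortho to a fused ring, gives a 1.0-fold higher number from compound 1 to compound 3 (0.00 log units; within the scatter) and forms the first step here between compounds that differ in one place. Compound 1 and compound 2 differ in more than one place, so they could not speak for this exchange alone; this pair shows that chloro and trifluoromethyl at this position give readings that cannot be told apart on these cells. No measured evidence bears on why the two groups read alike.

The compounds shown leave open whether a different kind of group, such as an amine or a carboxylic acid, on this same aromatic carbon would also stay within the scatter of compound 1, and so whether this position responds to substitution at all. They also leave open whether the exchange of chloro for trifluoromethyl would read the same way on a core that differs elsewhere, as that of compound 2 does.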